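A few compounds are considered here, and "the series" means these few. Any claim that something is new, unique, unknown or untested is made for them only; others in the source may bear on it.

Measured so far in an assay on brain for binding affinity to Neuronal acetylcholine receptor; alpha4/beta2 (Rattus norvegicus), read by radioligand binding; a higher number here means a weaker inhibitor, a lower number a stronger inhibitor:
compound 1 `C=Cc1ccc(OC[C@@H]2CCN2)cn1`, compound 1 gives 1.25 nM
compound 2 `Brc1cncc(OC[C@@H]2CCN2)c1`, compound 2 gives 0.18 nM
compound 3 `FC(F)(F)c1cncc(OC[C@@H]2CCN2)c1`, compound 3 gives 0.49 nM

Among these three numbers compound 3 stands second highest. Its nearest neighbour is compound 1, whose number is higher, and its furthest is compound 2, whose number is lower. Going by the values given here, the only single-point step among the measured compounds runs a 2.7-fold higher number from compound 2 to compound 3 (0.43 log units; beyond the scatter), where trifluoromethyl replaced bromo on an aromatic carbon.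

The new compound 4 `CCc1cncc(OC[C@@H]2CCN2)c1` differs from compound 3 in one place: ethyl in place of trifluoromethyl on an aromatic carbon.

Which measured step bears on this change? Among the compounds with values here, only the step from compound 2 to compound 3 involves the same position, and it exchanged one group for another of different character; it says nothing direct about an ethyl group. Both groups that swap here are small carbon substituents without donors or acceptors, so no large shift is the natural starting expectation. The number for compound 4 is therefore expected to stay close to that of compound 3, with the step of a 1.2-fold higher number from compound 3 to compound 4 (0.09 log units; within the scatter) expected to lie within the scatter. On that basis compound 4 is estimated at 0.6 nM, with a range from 0.25 nM to 1.5 nM.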

Compound 4, inhibition constant: 0.1 nM
Compound 4: the middle estimate sits 6.0-fold (0.78 log units) above what was measured; measured number below the stated range.
By their numbers in this assay, from the lowest: compounds 4 and 2 (each within the scatter of the next); then compound 3; then compound 1.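

In this assay, the step with ethyl in place of trifluoromethyl is a 4.9-fold lower number from compound 3 to compound 4 (0.69 log units; beyond the scatter) and lies beyond the scatter, so the number at this position can move even when the swap is between two groups with no hydrogen-bond donors or acceptors. The earlier compounds showed only that trifluoromethyl gave a higher number than bromo; the new step of a 1.8-fold lower number from compound 2 to compound 4 (0.26 log units; within the scatter) lies within the scatter, so ethyl and bromo cannot be told apart here, and among these three groups trifluoromethyl alone stands apart, with the higher number. Nothing measured here explains why the number moves with these groups.

The compounds shown leave open whether a longer chain such as propyl, or a group of a different kind such as an amine or a carboxylic acid, would keep the number as low as ethyl and bromo do at this position. They also leave open whether the gap between ethyl and trifluoromethyl would persist if another part of the shared core were changed.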